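Amide Variation at the Carbonyl of a Shared Core

The source may hold more compounds than are shown below. What is called first, only, known or untested is meant among the compounds shown, and "the series" means these compounds.

Of the compounds shown here, three sharing one core have been measured in a functional assay on HCT-116 cells (Homo sapiens) for antiproliferative activity, read by sulforhodamine B assay, with a stated time of 72 h; a higher number here means a weaker inhibitor, a lower number a stronger inhibitor. Compound 1 `CCOC(=O)c1cnc2ccc(-c3cnc(OC)c(NS(=O)(=O)c4ccc(F)cc4F)c3)cn12` carries an ethyl ester on that core and gives 90 nM in this assay. Compound 2 `COc1ncc(-c2ccc3ncc(C(=O)O)n3c2)cc1NS(=O)(=O)c1ccc(F)cc1F`, the free acid, gives 1310 nM, and compound 3 `COc1ncc(-c2ccc3ncc(C(=O)N4CCC(O)CC4)n3c2)cc1NS(=O)(=O)c1ccc(F)cc1F`, the 4-hydroxypiperidine amide, gives 490 nM. Among these three numbers compound 3 stands second highest: its nearest neighbour is compound 2, with a 2.7-fold lower number from compound 2 to compound 3 (0.43 log units; beyond the scatter), and its furthest is compound 1, with a 5.4-fold higher number from compound 1 to compound 3 (0.74 log units; beyond the scatter). The ester-to-acid step, a 15-fold higher number from compound 1 to compound 2 (1.16 log units; beyond the scatter), shows that substitution on this carbonyl carbon can move the number a long way.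

Compound 4 `COc1ncc(-c2ccc3ncc(C(=O)NCc4ccncc4)n3c2)cc1NS(=O)(=O)c1ccc(F)cc1F` is the next variant at the same place: ((pyridin-4-yl)methyl)amino in place of 4-hydroxypiperidin-1-yl on a carbonyl carbon. For the measured compounds named here, no measured step exchanges one amide for another, so the closest guide is the set of three carbonyl substituents already seen, which span from the ester of compound 1 to the acid of compound 2 with compound 3 in between. A secondary amide is expected to land somewhere in that span, and the step of a 1.6-fold lower number from compound 3 to compound 4 (0.21 log units; within the scatter) is therefore expected to be modest, with direction uncertain. Compound 4 is estimated at 300 nM, with a range from 70 nM to 1300 nM.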

Compound 4, half-maximal inhibitory concentration: 310 nM
Compound 4: the middle estimate sits 1.0-fold (0.01 log units) below what was measured, within the range that was stated.
By their numbers in this assay, from the lowest: compound 1; then compounds 4 and 3 (each within the scatter of the next); then compound 2.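

Replacing 4-hydroxypiperidin-1-yl with ((pyridin-4-yl)methyl)amino on the carbonyl carbon exchanges one amide for another and gives a 1.6-fold lower number from compound 3 to compound 4 (0.20 log units; within the scatter) in this assay, so a six-membered non-aromatic ring and a six-membered aromatic ring on this amide are not told apart here. The new amide also fixes a second point in the span between the acid and the ester: a 4.2-fold lower number from compound 2 to compound 4 (0.63 log units; beyond the scatter) on one side and a 3.4-fold higher number from compound 1 to compound 4 (0.54 log units; beyond the scatter) on the other, both beyond the scatter, as the corresponding steps of compound 3 are. Nothing available explains why the two amides read alike, or why both are separated from the ester and the acid.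

Two amides cannot show whether the ring nitrogen of the pyridine matters, which a (phenylmethyl)amino group on the same carbonyl carbon would address, or whether a longer chain between the amide nitrogen and the ring would change the number. From the compounds shown here alone, it also remains open whether a small amide such as ethylamino, which most closely matches the ethoxy of compound 1, would come nearer to the ester than either amide does.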